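Adding a methoxy group to compound 1

The source may report more compounds than this note shows. Statements on the series, on what has been measured and on what is new or still open speak of the compounds shown alone.

Compound 1 `Cc1ccccc1C(=O)NN(C(=O)c1ccccc1Cl)C(C)(C)C`: 72.4 nM
Compound 2 `CC(C)(C)N(NC(=O)c1cccc(Cl)c1)C(=O)c1ccccc1Cl`: 155 nM
Compound 3 `CC(C)(C)N(NC(=O)c1ccc(F)cc1)C(=O)c1ccccc1Cl`: 389 nM

These three compounds were measured in an assay on cells for agonist activity at ecdysone receptor (Bombyx mori), read by a luciferase reporter, with a stated time of 24 h; on this read-out lower numbers stand for an effect already at smaller amounts and higher numbers for an effect only at larger amounts of compound. Compound 1 gives the lowest number of the three in this assay, with 72.4 nM. Compound 2 sits nearest to it, and compound 3 furthest away. Both compounds differ from compound 1 only in the ring attached to one carbonyl carbon: the step of a 2.1-fold higher number from compound 1 to compound 2 (0.33 log units; beyond the scatter) and the step of a 5.4-fold higher number from compound 1 to compound 3 (0.73 log units; beyond the scatter) show that changing this ring shifts the read-out by a modest amount. Compound 4 `COc1cccc(C(=O)NN(C(=O)c2ccccc2Cl)C(C)(C)C)c1C` keeps the ring of compound 1 and adds one group to it: methoxy in place of hydrogen on an aromatic carbon. For the measured compounds named here, no measured pair adds a methoxy group in this way, so the known steps give only an indication that changes on this ring stay modest. The expectation for compound 4 in this assay is therefore a small step, a 1.2-fold higher number from compound 1 to compound 4 (0.09 log units; within the scatter), with no confident direction. The estimated value for compound 4 is 90 nM, with a range from 30 nM to 300 nM.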

Compound 4, half-maximal effective concentration: 15.5 nM
Beside the measured number, compound 4's estimate is 5.8-fold (0.76 log units) above it; measured number outside the range, below it.
By their numbers in this assay, from the lowest: compound 4; then compound 1; then compound 2; then compound 3.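

In this assay, placing a methoxy group on this ring gives a 4.7-fold lower number from compound 1 to compound 4 (0.67 log units; beyond the scatter), so this aromatic carbon, ortho to a methyl group and meta to a large group, tolerates an added group. The earlier compounds showed only replacements of the whole substituted ring, and both replacements raised the number relative to compound 1; this is the first change shown that lowers it. Nothing measured here explains the drop.

Only methoxy is shown at this position, so it remains open whether a hydroxyl group, an ethoxy group or a chlorine atom there would lower the number as well. Going by these compounds, it is also open whether methoxy would have the same effect on a ring without the neighbouring methyl group.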